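A few compounds are considered here, and "the series" means these few. Any claim that something is new, unique, unknown or untested is made for them only; others in the source may bear on it.

Measured in an ADME assay on U2OS cells (Homo sapiens) for cytotoxicity; on this read-out lower numbers stand for higher toxicity in this test and higher numbers for lower toxicity in this test:
compound 1 `CCSc1ccc(-c2nccc3[nH]c(C(C)(C)O)cc23)cc1`: 17200 nM
compound 2 `CC(C)(O)c1cc2c(-c3ccc(C(F)(F)F)cc3)nccc2[nH]1`: 72300 nM
compound 3 `CC(C)(O)c1cc2c(-c3ccc(F)cc3)nccc2[nH]1`: 93600 nM

Compound 3, at 93600 nM, sits at the upper end of this small set together with compound 2, at 72300 nM, the two lying within the scatter of each other. Both stand clear of the ethylsulfanyl member, as shown by a 5.4-fold higher number from compound 1 to compound 3 (0.74 log units; beyond the scatter) and a 4.2-fold higher number from compound 1 to compound 2 (0.62 log units; beyond the scatter).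

Compound 4 `Cc1ccc(-c2nccc3[nH]c(C(C)(C)O)cc23)cc1` carries methyl in place of fluoro on an aromatic carbon, para to a large group. All three measured steps change this same place. The closest guide is a 1.3-fold higher number from compound 2 to compound 3 (0.11 log units; within the scatter), a swap between the two groups that leaves the number within the scatter. The steps from compound 1 serve only as an outer bound, since ethylsulfanyl is a much larger group than methyl.

A small move towards a lower number, within the scatter, is therefore expected, and the expected step is a 1.4-fold lower number from compound 3 to compound 4 (0.16 log units; within the scatter). For compound 4 the estimate is 65000 nM, with an expected range of 28000 nM to 120000 nM.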

Compound 4, half-maximal cytotoxic concentration: 38500 nM
Compound 4: middle estimate off by 1.7-fold (0.23 log units), on the high side; the measured number falls inside the stated range.
By their numbers in this assay, from the lowest: compound 1; then compounds 4, 2 and 3 (each within the scatter of the next, the first and the last beyond it).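

In this assay, within the data shown here, the change from fluoro to methyl on this aromatic carbon, para to a large group, gives a step beyond the scatter (a 2.4-fold lower number from compound 3 to compound 4 (0.39 log units; beyond the scatter)), the first such step here between two groups other than ethylsulfanyl. Yet methyl and trifluoromethyl remain within the scatter of each other (a 1.9-fold lower number from compound 2 to compound 4 (0.27 log units; within the scatter)), so the three single-group variants do not separate cleanly, even though the fluoro and trifluoromethyl pair also lies within it. Compound 1 now sits beyond the scatter from methyl as well (a 2.2-fold higher number from compound 1 to compound 4 (0.35 log units; beyond the scatter)), which leaves ethylsulfanyl as the lowest of the four, and nothing at hand gives a reason for these differences.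

Open, going by these compounds, is where an amine, a carboxylic acid or a methoxy group at this place would fall. Also open, on these data alone, is whether a methylsulfanyl or a longer thioether chain would track compound 1.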